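Piperidin-1-yl in place of tetrahydroisoquinolinyl on the shared core

The compounds below may be only part of what the source reports. "The series", "measured", "known", "first", "only" and "open" are said of these compounds alone.

Compound 1 `c1cc(N2CCCCC2)nc(Nc2ccc(Oc3ncnc4sccc34)cc2)n1`: 4020 nM
Compound 2 `c1ccc2c(c1)CCN(c1ccnc(Nc3ccc(Oc4ncnc5ccsc45)cc3)n1)C2`: 17000 nM

In a functional assay on A549 cells (Homo sapiens) for inhibition, read by MTT assay, with a stated time of 72 h (on this read-out lower numbers stand for stronger inhibition and higher numbers for weaker inhibition), compound 2 gives 17000 nM, the highest of the two numbers. The nearest, compound 1, gives 4020 nM, a gap beyond the usual scatter. Compound 3 `c1cc(N2CCCCC2)nc(Nc2ccc(Oc3ncnc4ccsc34)cc2)n1` differs from compound 2 by piperidin-1-yl in place of 1,2,3,4-tetrahydroisoquinolin-2-yl on an aromatic carbon. For the measured compounds named here, no measured pair isolates this change. The step of a 3.1-fold lower number from compound 2 to compound 3 (0.49 log units; beyond the scatter) is expected to run toward a lower number, because compound 1 carrying the same piperidin-1-yl gives 4020 nM in this assay. Compound 3 is therefore estimated at 5500 nM, within 1800 nM to 17000 nM.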

Compound 3, half-maximal inhibitory concentration: 7800 nM
Compound 3: the middle estimate sits 1.4-fold (0.15 log units) below what was measured, within the range that was stated.
By their numbers in this assay, from the lowest: compounds 1 and 3 (each within the scatter of the next); then compound 2.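

In this assay, the exchange on the aromatic carbon next to the ring nitrogen now has a direct measure: a 2.2-fold lower number from compound 2 to compound 3 (0.34 log units; beyond the scatter), a modest step toward stronger inhibition with piperidin-1-yl. With piperidin-1-yl held in place, the change in the group on the oxygen gives a 1.9-fold higher number from compound 1 to compound 3 (0.29 log units; within the scatter), so this read-out does not separate those two groups. Nothing available explains either step. On these data alone, whether morpholin-4-yl or an open-chain amine such as dimethylamino at this position would lower the number further remains open.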